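Aryl Swap on the Urea Nitrogen of a Thienopyrimidine

The compounds below may be only part of what the source reports. "The series", "measured", "known", "first", "only" and "open" are said of these compounds alone.

Measured compounds:
compound 1, `CCN(CC)CCCNc1nc(-c2ccc(NC(=O)Nc3ccc(F)cc3)cc2)nc2ccsc12`, in a functional assay on NCI-H460 cells (Homo sapiens) for cytotoxicity, read by MTT assay, with a stated time of 72 h (a lower number here means a stronger inhibitor, a higher number a weaker inhibitor), compound 1 gives 290 nM.
compound 2, `CCN(CC)CCCNc1nc(-c2ccc(NC(=O)Nc3ccccc3Cl)cc2)nc2ccsc12`, in this assay compound 2 gives 200 nM.

Among the compounds with values here, compound 2 holds the lower of the two numbers, and the only step between them, a 1.5-fold lower number from compound 1 to compound 2 (0.16 log units; within the scatter), does not separate them. Compound 3, `CCN(CC)CCCNc1nc(-c2ccc(NC(=O)Nc3ccc(C)cc3)cc2)nc2ccsc12`, carries 4-methylphenyl in place of 2-chlorophenyl on an amide-type nitrogen. Within the data shown here, the one step that bears on this place, an exchange of one aryl group for another on the same amide-type nitrogen, stayed within the scatter, so no step beyond the scatter is expected in this assay. Compound 3 is therefore estimated at 250 nM, expected between 100 nM and 600 nM. That estimate for compound 3 means an expected step of a 1.3-fold higher number from compound 2 to compound 3 (0.10 log units; within the scatter).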

Compound 3, half-maximal inhibitory concentration: 1240 nM
Compound 3: the middle estimate sits 5.0-fold (0.70 log units) below what was measured; measured number outside the range, above it.
By their numbers in this assay, from the lowest: compounds 2 and 1 (each within the scatter of the next); then compound 3.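

In this assay, the exchange of 4-methylphenyl for 2-chlorophenyl on this amide-type nitrogen gives a 6.2-fold higher number from compound 2 to compound 3 (0.79 log units; beyond the scatter) and the exchange of methyl for fluoro on an aromatic carbon gives a 4.3-fold higher number from compound 1 to compound 3 (0.63 log units; beyond the scatter) so this position does respond to the choice of aryl group, which the earlier swap within the scatter did not show. No measurement given here accounts for the rise.

Whether the methyl group alone sets compound 3 apart remains open, since a methoxy or trifluoromethyl group on the same ring is not among the compounds shown. An unsubstituted phenyl group, which would give a reference for all three aryl groups, is also absent.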